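The source may hold more compounds than are shown below. What is called first, only, known or untested is meant among the compounds shown, and "the series" means these compounds.

In a physicochemical assay for lipophilicity, using the shake flask method (on this read-out higher numbers stand for higher lipophilicity and lower numbers for lower lipophilicity), compound 1 (`C[C@H](Oc1ccc2ncc(CCC(=O)O)c(C3CC3)c2c1)c1c(Cl)ccc(F)c1Cl`) gives 4.1, and compound 2 (`C[C@H](Oc1ccc2ncc(/C=C/C(=O)O)c(C3CC3)c2c1)c1c(Cl)ccc(F)c1Cl`) gives 4.1, so compound 2 stands level with compound 1. Compound 3 (`C[C@H](Oc1cc(CO)c2ncc(/C=C/C(=O)O)c(C3CC3)c2c1)c1c(Cl)ccc(F)c1Cl`) has not yet been measured. It differs from compound 2 by hydroxymethyl in place of hydrogen on an aromatic carbon. Among the compounds with values here, only one measured step is available, no change at the digits printed from compound 1 to compound 2 (within the scatter). That step concerns a different group, so it bears only loosely on this change and gives no measured size for adding hydroxymethyl. The expectation therefore starts from compound 2 at 4.1 and allows for a wide range. Within the data shown here, a moderate step downward in this assay is expected, although no measured compound yet shows it, and the estimate is a number 0.50 log units lower from compound 2 to compound 3 (beyond the scatter). For compound 3 the estimated value is 3.6, with an expected range from 3.1 to 4.1.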

Compound 3, distribution coefficient: 2.9
The estimate for compound 3 lay 0.70 log units above the measured number, and the stated range ends above it.
By their numbers in this assay, from the lowest: compound 3; then compounds 1 and 2 (each within the scatter of the next).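

In this assay, within the data shown here, hydroxymethyl in place of hydrogen on this aromatic carbon gives a number 1.20 log units lower from compound 2 to compound 3 (beyond the scatter) and is the only step here that lies beyond the scatter. The earlier change, 2-carboxyethenyl in place of 2-carboxyethyl, gave no change at the digits printed from compound 1 to compound 2 (within the scatter) and so showed no movement, whereas this position on the shared core moves the read-out by a large step when hydroxymethyl enters. Nothing measured here explains the size of this step.

As far as these compounds go, whether the step belongs to hydroxymethyl itself or would come with other groups on this carbon stays open, and a methyl, a methoxy, a fluorine or an aminomethyl there would help separate those readings. From the compounds shown here alone, it is also open whether hydroxymethyl would give a step of similar size alongside the 2-carboxyethyl chain of compound 1.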